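A few compounds are considered here, and "the series" means these few. Any claim that something is new, unique, unknown or untested is made for them only; others in the source may bear on it.

In a functional assay on CCRF-CEM cells (Homo sapiens) for antiproliferative activity, read by cell counting, with a stated time of 72 h (on this read-out higher numbers stand for weaker inhibition and lower numbers for stronger inhibition), compound 1 (`C#C[C@@]1(O)[C@@H](CO)O[C@@H](n2cnc3c(-c4ccc(C)cc4)ncnc32)[C@@H]1O`) gives 154000 nM and compound 2 (`C#C[C@@]1(O)[C@@H](CO)O[C@@H](n2cnc3c(-c4ccc(F)cc4)ncnc32)[C@@H]1O`) gives 223000 nM. Compound 3 (`C#C[C@@]1(O)[C@@H](CO)O[C@@H](n2cc(F)c3c(N)ncnc32)[C@@H]1O`) gives 160 nM, the lowest of the three numbers. The next compound, compound 4 (`C#C[C@@]1(O)[C@@H](CO)O[C@@H](n2cc(C(F)(F)F)c3c(N)ncnc32)[C@@H]1O`), keeps everything in compound 3 except for one group, with trifluoromethyl in place of fluoro on an aromatic carbon.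

Within the data shown here, only one measured step compares two small groups, a 1.4-fold higher number from compound 1 to compound 2 (0.16 log units; within the scatter), and it lies within the scatter. That step swaps fluoro for methyl in another part of the molecule, so it offers only weak guidance here. Among the measured compounds shown here, no measured step covers the place that changes now. For the measured compounds named here, with compound 3 at 160 nM holding the lowest number so far, a rise seems more likely than a further fall, though the uncertainty is wide. The estimate amounts to an expected 6.3-fold higher number from compound 3 to compound 4 (0.80 log units; beyond the scatter). For compound 4 the estimated value is 1000 nM, with an expected range of 150 nM to 10000 nM.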

Compound 4, half-maximal inhibitory concentration: 360 nM
The estimate for compound 4 lay 2.8-fold (0.44 log units) above the measured number, within the range that was stated.
By their numbers in this assay, from the lowest: compound 3; then compound 4; then compounds 1 and 2 (each within the scatter of the next).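

In this assay the swap of fluoro for trifluoromethyl gives a 2.3-fold higher number from compound 3 to compound 4 (0.35 log units; beyond the scatter) and so counts as a modest rise beyond the scatter, even though the group grows from 1 heavy atom to 4 heavy atoms. This aromatic carbon of the five-membered ring, two ring bonds from the ring nitrogen, therefore accepts the larger of these two groups with only a small change in the number. The data shown offer no measurement that could explain this step.

Going by these compounds, whether an amine, a carboxylic acid or a longer chain such as ethyl would fare as well at this place remains open. With only fluoro and trifluoromethyl to compare here, two points cannot establish how the number follows the size of the group.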